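The compounds below may be only part of what the source reports. "The series", "measured", "known", "first", "only" and "open" are said of these compounds alone.

Compound 1 `COc1ccc(C(=O)CC2CC(=O)N(c3ccc(S(N)(=O)=O)cc3)C2=O)cc1` gives 4740 nM in an assay on cells (1-87 tumor cell line) for inhibition of Polyunsaturated fatty acid 5-lipoxygenase (Homo sapiens), with a stated time of 5 min; on this read-out higher numbers stand for weaker inhibition and lower numbers for stronger inhibition. Compound 2 `Cc1ccc(C(=O)CC2CC(=O)N(c3ccc(S(N)(=O)=O)cc3)C2=O)cc1` gives 860 nM in this assay.

Of these two, compound 2 stands at the lower number, and the step of a 5.5-fold lower number from compound 1 to compound 2 (0.74 log units; beyond the scatter) lies beyond the scatter. Compound 3 `NS(=O)(=O)c1ccc(N2C(=O)CC(CC(=O)c3ccccc3)C2=O)cc1` has not been measured; it differs from compound 2 by hydrogen in place of methyl on an aromatic carbon, on an aromatic carbon of a six-membered aromatic ring of carbon only, para to a large group. Only the methoxy-to-methyl step bears on this change, and it shows that the group at this place matters, but removing the methyl altogether is a different change, so no clear direction follows. For compound 3 a step of a 1.6-fold higher number from compound 2 to compound 3 (0.21 log units; within the scatter) is expected, not clearly beyond the scatter. Compound 3 is estimated at 1400 nM, between 500 nM and 4000 nM.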

Compound 3, half-maximal inhibitory concentration: 5290 nM
The estimate for compound 3 lay 3.8-fold (0.58 log units) below the measured number, outside the stated range (above it).
By their numbers in this assay, from the lowest: compound 2; then compounds 1 and 3 (each within the scatter of the next).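

In this assay, taking the methyl away is not a neutral change (a 6.2-fold higher number from compound 2 to compound 3 (0.79 log units; beyond the scatter)), so the lower number of compound 2 depends on the methyl itself. Hydrogen and methoxy at this place cannot be told apart (a 1.1-fold higher number from compound 1 to compound 3 (0.05 log units; within the scatter)), so among these three groups only methyl stands out. Nothing measured here explains why this is so.

Still open, from the compounds shown here alone, is whether a longer chain such as ethyl, or a chlorine atom or an amine on this aromatic carbon, would match compound 2, fall back towards the hydrogen and methoxy compounds, or go lower still.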